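This account rests on a few compounds, and the source may have more. Where it says the series, first, only, none or still open, it means among the compounds named here.

Compound 1 `CCNC(=S)Nc1cccc(C(F)(F)F)c1`, compound 2 `FC(F)(F)c1cccc(NC(=S)Nc2ccc(Cl)cc2)c1` and compound 3 `CC[C@H]1CC[C@H](c2ccc(NC(=S)Nc3cccc(C(F)(F)F)c3)cc2)CC1` share a thiourea core bearing a 3-(trifluoromethyl)phenyl group. In an ADME assay on MDBK cells (Bos taurus) for cytotoxicity, read by MTT assay, with a stated time of 96 h (on this read-out lower numbers stand for higher toxicity in this test and higher numbers for lower toxicity in this test), compound 1 gives a value of > 100000 nM, which is a limit of the assay rather than a number (the limit of > 100000 nM in this assay, at which 1 of the 3 values shown sits). In this assay compound 2 gives 17000 nM, the highest of the two numbers shown, while compound 3 gives 9000 nM; the two are within the scatter of each other. The measured steps are an at least 5.8-fold lower number from compound 1 to compound 2 (0.76 log units; beyond the scatter) and a 1.9-fold lower number from compound 2 to compound 3 (0.28 log units; within the scatter).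

Compound 4 `FC(F)(F)c1cccc(NC(=S)NCc2ccco2)c1` differs from compound 2 in one place: (furan-2-yl)methyl in place of 4-chlorophenyl on an amide-type nitrogen. Going by the values given here, the step that bears on this change is the one from compound 1 to compound 2, in which an aryl group in place of a small alkyl group on the same nitrogen brought an at least modest lowering. Replacing that aryl group with a (furan-2-yl)methyl group is therefore expected to move the number back upward, by a 2.9-fold higher number from compound 2 to compound 4 (0.47 log units; beyond the scatter), though possibly only to a limit. Compound 4 is estimated at 50000 nM, within 15000 nM to 150000 nM.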

Compound 4, half-maximal cytotoxic concentration: > 100000 nM
Compound 4 was reported as a limit (the forecaster's own chance of this, stated with the estimate: 40%); at least 2.0-fold (0.30 log units) between middle value and limit.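

In this assay, (furan-2-yl)methyl in place of 4-chlorophenyl on the amide-type nitrogen gives an at least 5.8-fold higher number from compound 2 to compound 4 (0.76 log units; beyond the scatter). The earlier compounds shown here showed only that ethyl and 4-chlorophenyl differ at this place; compound 4 adds that a ring on this nitrogen does not by itself bring the lower number seen for compound 2. The reading for compound 4 is a limit and not a number, and compound 1 shares it: the limit of > 100000 nM in this assay, at which 2 of the 4 values shown sit.

Going by these compounds, the step between compound 1 and compound 4 cannot be read, so their order remains unknown. The compounds shown also leave open whether the higher number follows from the furan ring, the saturated chain carbon or the loss of chlorine, a question that a benzyl or 4-chlorobenzyl group on this nitrogen would bear on.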